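Swapping the anilide aryl group on a shared core

This account rests on a few compounds, and the source may have more. Where it says the series, first, only, none or still open, it means among the compounds named here.

Compound 1 `Cc1ccc(Nc2ncc(C(F)(F)F)c(N3Cc4cccc(N(C)S(C)(=O)=O)c4C3)n2)cc1C` carries a 3,4-dimethylphenyl group on a nitrogen attached to the shared core. In a functional assay on HeLa cells (Homo sapiens) for antiproliferative activity, read by spectrophotometry, with a stated time of 2 days (a higher number here means a weaker inhibitor of growth, a lower number a stronger inhibitor of growth), compound 1 gives only a limit, > 30000 nM, which is the edge of what the measurement reports rather than a number (the limit of > 30000 nM in this assay, at which 1 of the 3 values shown sits). Two close relatives have been measured with numbers. Among the measured compounds shown here, compound 2 `Cc1ccc(Nc2ncc(C(F)(F)F)c(N3Cc4cccc(N(C)S(C)(=O)=O)c4C3)n2)c(Cl)c1` gives 10900 nM in this assay, and the change an at least 2.7-fold lower number from compound 1 to compound 2 (0.43 log units; beyond the scatter) is the one measured step that starts from compound 1. Compound 3 `CN(c1cccc2c1CN(c1nc(Nc3cc(C(F)(F)F)cc(C(F)(F)F)c3)ncc1C(F)(F)F)C2)S(C)(=O)=O`, which carries a 3,5-bis(trifluoromethyl)phenyl group in the same place, gives 9200 nM in this assay.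

Compound 4 `CN(c1cccc2c1CN(c1nc(Nc3cccc(C(F)(F)F)c3)ncc1C(F)(F)F)C2)S(C)(=O)=O` has not yet been measured. It differs from compound 1 by 3-(trifluoromethyl)phenyl in place of 3,4-dimethylphenyl on a nitrogen on an aromatic ring. For the measured compounds named here, the one measured step from compound 1 points toward a lower number, and compound 3 sits in the same region as compound 2, so a step of similar size is expected from compound 1 to compound 4, an at least 2.5-fold lower number from compound 1 to compound 4 (0.39 log units; beyond the scatter). Compound 4 is therefore estimated to give about 12000 nM in this assay, most likely between 4000 nM and 30000 nM.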

Compound 4, concentration for 50% growth inhibition: 5300 nM
The estimate for compound 4 lay 2.3-fold (0.35 log units) above the measured number; low and high end bracket the measured number.
By their numbers in this assay, from the lowest: compounds 4, 3 and 2 (each within the scatter of the next, the first and the last beyond it). At a limit, above all of these: compound 1.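

On this nitrogen, the second trifluoromethyl group of compound 3 makes no difference that this assay can resolve: a 1.7-fold lower number from compound 3 to compound 4 (0.24 log units; within the scatter) is the step on removing it. The comparison with another substitution pattern does separate, though only modestly, with a 2.1-fold lower number from compound 2 to compound 4 (0.31 log units; beyond the scatter) on going to 3-(trifluoromethyl)phenyl. Replacing 3,4-dimethylphenyl with that same group gives an at least 5.6-fold lower number from compound 1 to compound 4 (0.75 log units; beyond the scatter) and this size is only a bound, since one end of the step is a limit: the limit of > 30000 nM in this assay, at which 1 of the 4 values shown sits.

All the groups shown here are phenyl rings carrying methyl, chlorine or trifluoromethyl, so the effect of an amine, a carboxylic acid or a nitrile on that ring remains open. Also open, going by these compounds, is whether any group on this nitrogen can give a much lower number than those seen so far.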